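This account rests on a few compounds, and the source may have more. Where it says the series, first, only, none or still open, it means among the compounds named here.

Compound 2, `CC(C)=CCC[C@]1(C)/C=C/[C@@H](OC(=O)C=C(C)C)[C@](C)(O)/C=C/C(=O)/C(C[Si](C)(C)C(C)(C)C)=C\C1`, is a close relative of compound 1, `CC[Si](CC)(CC)C/C1=C/C[C@](C)(CCC=C(C)C)/C=C/[C@@H](OC(=O)C=C(C)C)[C@](C)(O)/C=C/C1=O`. In a functional assay on HL-60 cells (Homo sapiens) for antiproliferative activity, read by MTT assay, with a stated time of 48 h (on this read-out higher numbers stand for weaker inhibition and lower numbers for stronger inhibition), compound 1 gives 2810 nM, and compound 2 gives 2770 nM. For the measured compounds named here, the single step measured so far, a 1.0-fold lower number from compound 1 to compound 2 (0.01 log units; within the scatter), exchanges one silicon-bearing group for another on a saturated chain carbon bound to a double-bonded ring carbon. On the two numbers in hand, compound 2 has the lowest value, with compound 1 nearest, and the two lie within the scatter of each other, so no order between them can be claimed.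

Compound 3, `CC(C)=CCC[C@]1(C)/C=C/[C@@H](OC(=O)C=C(C)C)[C@](C)(O)/C=C/C(=O)/C(C(=O)N2CCCC2)=C\C1`, departs further: a group of 7 heavy atoms (5 carbon, 1 nitrogen, 1 oxygen; one five-membered non-aromatic ring with 1 hetero atom) in place of a group of 8 heavy atoms (7 carbon, 1 silicon; no ring), on a double-bonded ring carbon. The group that enters, (pyrrolidin-1-yl)carbonyl, brings a five-membered ring with one nitrogen and one hydrogen-bond acceptor where before there was a chain carrying silicon and no acceptor. Going by the values given here, the one measured step does not bear on this change, since it only swapped one silicon-containing group for another and stayed within the scatter. Compound 3 is therefore estimated near the values already seen, with an expected step of a 1.1-fold higher number from compound 2 to compound 3 (0.03 log units; within the scatter) in this assay, and wide uncertainty. For compound 3 the estimate is 3000 nM, within a range from 600 nM to 15000 nM.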

Compound 3, half-maximal inhibitory concentration: 12300 nM
For compound 3 the middle estimate is 4.1-fold (0.61 log units) below the measured one; the range from low to high includes it.
By their numbers in this assay, from the lowest: compounds 2 and 1 (each within the scatter of the next); then compound 3.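

In this assay, this double-bonded ring carbon proves sensitive to what it carries: the two silicon-bearing groups could not be told apart, but putting (pyrrolidin-1-yl)carbonyl in their place gives a 4.4-fold higher number from compound 2 to compound 3 (0.65 log units; beyond the scatter) and a 4.4-fold higher number from compound 1 to compound 3 (0.64 log units; beyond the scatter). This is the first change among these compounds to go beyond the scatter, and it moves toward weaker inhibition, though the size of the step is modest and compound 3 still gives a measured 12300 nM. Nothing at hand accounts for the shift.

The exchange replaces the silicon-bearing chain with a carbonyl, a nitrogen and a five-membered ring all at once, so the compounds shown leave open which of these goes with the weaker inhibition. A silicon-free alkyl chain such as a hexyl group would address the silicon, while an open-chain dimethylaminocarbonyl group, a piperidin-1-ylcarbonyl group or a free carboxylic acid at the same ring carbon would address the ring and the nitrogen.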